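The compounds below may be only part of what the source reports. "The series", "measured", "known", "first", "only" and "open" are said of these compounds alone.

The study follows four compounds in a functional assay on DU-145 cells (Homo sapiens) for cytotoxicity, read by trypan blue exclusion, with a stated time of 96 h; a lower number here means a stronger inhibitor, a higher number a weaker inhibitor. Compound 1 `COc1ccc(/C=C/S(=O)(=O)Nc2ccc(F)cc2)cc1` gives 10000 nM, and compound 2 `COc1ccc(/C=C/S(=O)(=O)Nc2ccc(OC)cc2)cc1` gives 5000 nM. These two differ in one place: fluoro in place of methoxy on an aromatic carbon. That change made a step of a 2.0-fold higher number from compound 2 to compound 1 (0.30 log units; within the scatter). Compound 3 `COc1cc(OC)c(/C=C/S(=O)(=O)Nc2ccc(OC)c([N+](=O)[O-])c2)c(OC)c1` carries a different core; the difference between its core and the core of compound 2 is not broken down here. In this assay compound 3 gives 2500 nM, which stands within the scatter of compound 2 and beyond the scatter only against compound 1.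

Compound 4 `COc1cc(OC)c(/C=C/S(=O)(=O)Nc2ccc(F)c([N+](=O)[O-])c2)c(OC)c1` has not yet been measured. It differs from compound 3 by fluoro in place of methoxy on an aromatic carbon. For the measured compounds named here, this is the same kind of change as the one from compound 2 to compound 1, not the same: here the place is also ortho to a nitro group (3 heavy atoms). The earlier step was a 2.0-fold higher number from compound 2 to compound 1 (0.30 log units; within the scatter). On that basis the new step is expected to be a 2.0-fold higher number from compound 3 to compound 4 (0.30 log units; within the scatter). Going by the values given here, compound 4 is therefore estimated at 5000 nM, between 2000 nM and 12500 nM, resting on a 2.0-fold higher number from compound 2 to compound 1 (0.30 log units; within the scatter) as the only comparable step.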

Compound 4, half-maximal inhibitory concentration: 100000 nM
Estimate against measurement, compound 4: 20-fold (1.30 log units) below, outside the stated range (above it).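

In this assay, putting fluoro in place of methoxy on an aromatic carbon gave a 40-fold higher number from compound 3 to compound 4 (1.60 log units; beyond the scatter), a large step. Set beside the earlier step, the same change did not carry over from one core to the other: the same change on two cores in this assay, a 2.0-fold higher number (0.30 log units; within the scatter) from compound 2 to compound 1 and a 40-fold higher number (1.60 log units; beyond the scatter) from compound 3 to compound 4, 20-fold (1.30 log units) apart, beyond the scatter of two such steps. This shows that, across these two pairs, the step seen on one core was no guide to its size on the other, but two pairs cannot show which difference between the cores goes with the larger step, nor how the change would behave on any further core.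

The compounds shown leave open how an amine, a hydroxyl or a chloro group would fare at this place on the core of compound 3. They also leave open whether the nitro group, to which this place is ortho, or the other methoxy groups of that core set the two steps apart, and a pair carrying only one of these features would be needed to separate them.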